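Loss of 4-methoxybenzyl on an aromatic nitrogen: expected effect

The source may report more compounds than this note shows. Statements on the series, on what has been measured and on what is new or still open speak of the compounds shown alone.

Compound 2 `COc1ccc(Cn2nc(-c3ccccc3)c3cc(C(=N)Nc4ccc(N5CCN(C)CC5)cc4)nc(Nc4cc(OC)c(OC)c(OC)c4)c32)cc1` and compound 1 `COc1cc(Nc2nc(C(=N)Nc3ccc(N4CCN(C)CC4)cc3)cc3c(-c4ccccc4)n[nH]c23)cc(OC)c1OC` differ in one place, by hydrogen in place of 4-methoxybenzyl on an aromatic nitrogen. In a functional assay on HT-1080 cells (Homo sapiens) for cytotoxicity, read by MTT assay, with a stated time of 72 h (a higher number here means a weaker inhibitor, a lower number a stronger inhibitor), compound 2 gives 1200 nM, while compound 1 gives 3400 nM; the step is a 2.8-fold higher number from compound 2 to compound 1 (0.45 log units; beyond the scatter). For compound 3 `COc1ccc(Cn2nc(-c3ccccc3)c3cc(C(=N)Nc4cccc(C(F)(F)F)c4)nc(Nc4cc(OC)c(OC)c(OC)c4)c32)cc1` the result in this assay is "not determined" (no result reported), so no number is available for it. The difference between the cores of compound 2 and compound 3 is not broken down here. Compound 4 `COc1cc(Nc2nc(C(=N)Nc3cccc(C(F)(F)F)c3)cc3c(-c4ccccc4)n[nH]c23)cc(OC)c1OC` differs from compound 3 by hydrogen in place of 4-methoxybenzyl on an aromatic nitrogen, the same change as that from compound 2 to compound 1, at a place described in the same words. With no number for compound 3, the expectation for compound 4 rests on compound 1 at 3400 nM and on the size of a 2.8-fold higher number from compound 2 to compound 1 (0.45 log units; beyond the scatter). For compound 4 in this assay the expected value is 4000 nM, estimated to lie within 1000 nM to 16000 nM. The range is wide; the step of this change is known from one pair only, and the core of compound 4 is unmeasured.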

Compound 4, half-maximal inhibitory concentration: 6700 nM
Beside the measured number, compound 4's estimate is 1.7-fold (0.22 log units) below it, within the range that was stated.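

Among the compounds shown here, compound 3 has no number in this assay so no step from it to compound 4 can be read. Going by these compounds, whether hydrogen in place of 4-methoxybenzyl acts alike on the core of compound 4 stays open. Nothing shown bears on a cause.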